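The compounds below may be only part of what the source reports. "The series", "measured", "known", "first", "only" and "open" are said of these compounds alone.

Compound 1 `CCCCCCNC(=O)[C@H]1OC(n2cnc3c(N)ncnc32)[C@H](O)[C@@H]1O` is the starting point of this comparison. In an assay on cell membranes for binding affinity to 2-oxoglutarate receptor 1 (Rattus norvegicus), read by radioligand binding (on this read-out lower numbers stand for stronger inhibition and higher numbers for weaker inhibition), compound 1 gives 19 nM, the lowest number among the three measured compounds. Two longer-chain relatives have been measured. Compound 2 `CCCCCCCCCCCNC(=O)[C@H]1OC(n2cnc3c(N)ncnc32)[C@H](O)[C@@H]1O` gives 123 nM in this assay, and compound 3 `CCCCCCCCCCCCNC(=O)[C@H]1OC(n2cnc3c(N)ncnc32)[C@H](O)[C@@H]1O` gives 163 nM. Going a 6.5-fold higher number from compound 1 to compound 2 (0.81 log units; beyond the scatter) and an 8.6-fold higher number from compound 1 to compound 3 (0.93 log units; beyond the scatter), both of which mean weaker binding, while a 1.3-fold higher number from compound 2 to compound 3 (0.12 log units; within the scatter). Compound 4 `CCC(C)NC(=O)[C@H]1OC(n2cnc3c(N)ncnc32)[C@H](O)[C@@H]1O` has not yet been measured. It differs from compound 1 by sec-butyl in place of hexyl on an amide-type nitrogen, so the chain on the amide-type nitrogen becomes shorter and branched rather than longer. The measured steps only show what happens when the chain grows; nothing measured tells what a shorter or branched chain does. From the compounds shown here alone, since lengthening weakened binding, shortening is not expected to weaken it strongly, but the branching is untested, so a wide range is kept. Compound 4 is therefore expected to give about 40 nM in this assay, between 8 nM and 250 nM, which means an expected step of a 2.1-fold higher number from compound 1 to compound 4 (0.32 log units; beyond the scatter).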

Compound 4, inhibition constant: 198 nM
Compound 4: the middle estimate sits 5.0-fold (0.69 log units) below what was measured, within the range that was stated.
By their numbers in this assay, from the lowest: compound 1; then compounds 2, 3 and 4 (each within the scatter of the next).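

In this assay, sec-butyl in place of hexyl on the amide-type nitrogen gives a 10-fold higher number from compound 1 to compound 4 (1.02 log units; beyond the scatter), so shortening and branching the chain also weakens binding. Lengthening was therefore not the only change at this position that costs binding: compound 1, with its hexyl group, now binds more strongly than both the longer-chain compounds and the shorter branched one, and compounds 2, 3 and 4 lie within the scatter of one another. Nothing available explains the size of this step.

Sec-butyl changes both chain length and branching, so these compounds cannot show which of the two matters. A straight butyl chain would separate them, while a heptyl or octyl chain would show whether binding changes sharply on the longer side of hexyl.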